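Nicotinoyl hydrazones: pyridin-3-yl for phenyl in paw edema

This account rests on a few compounds, and the source may have more. Where it says the series, first, only, none or still open, it means among the compounds named here.

Measured compounds in a functional assay on the whole organism (strain Wistar) for inhibition, with Rattus norvegicus as the target, read by paw edema, with a stated time of 3 h, at a dose of 10 mg/kg by the intraperitoneal route; a lower number here means less inhibition, a higher number more inhibition at the dose given (going by the name of the read-out):
compound 1 `O=C(N/N=C/c1ccccc1)c1cccnc1Nc1cccc(C(F)(F)F)c1`, 21.2%
compound 2 `O=C(N/N=C/c1cccnc1)c1cccnc1Nc1cccc(C(F)(F)F)c1`, 52.4%
compound 3 `CNc1ncccc1C(=O)N/N=C/c1ccccc1`, 22.7%

Compound 1 and compound 3 share the hydrazone side chain but differ in their cores; the difference between the two cores is not broken down here. Their values in this assay lie within the scatter of each other. Among the measured compounds shown here, the one counted change, (pyridin-3-yl in place of phenyl on a carbon with a double bond to nitrogen), gives a number 31.2 percentage points higher from compound 1 to compound 2 (beyond the scatter).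

Compound 4 `CNc1ncccc1C(=O)N/N=C/c1cccnc1` is not yet measured. It differs from compound 3 by pyridin-3-yl in place of phenyl on a carbon with a double bond to nitrogen, the same change as from compound 1 to compound 2, at a place described in the same words. For the measured compounds named here, on the strength of the single step of a number 31.2 percentage points higher from compound 1 to compound 2 (beyond the scatter), a step of similar size is expected from compound 3, namely a number 27.3 percentage points higher from compound 3 to compound 4 (beyond the scatter), though only one prior instance supports it. For compound 4 the expected value in this assay is 50%, with a range of 32% to 66%.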

Compound 4, a percentage reported as inhibition, in the whole organism at one dose (the size of the read-out at that dose, not a potency): 27.7%
Estimate against measurement, compound 4: 22.3 percentage points above; the measured number lies below the stated range.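

In this assay, pyridin-3-yl in place of phenyl gives a number 5 percentage points higher from compound 3 to compound 4 (within the scatter) and therefore does not reproduce the gain seen on the core of compound 1, so the size of this step cannot be assumed to transfer between cores in this series: the same change on two cores in this assay, a number 31.2 percentage points higher (beyond the scatter) from compound 1 to compound 2 and a number 5 percentage points higher (within the scatter) from compound 3 to compound 4, 26.2 percentage points apart, beyond the scatter of two such steps

The step therefore depends on the core in these two pairs. Among the compounds shown here, with only two pairs, however, the data cannot show which part of the cores decides the outcome, and a reading at a single dose says nothing about potency.

Still open, on these data alone, is how the same change behaves on a core carrying a longer alkyl chain on the amine nitrogen. Also open, as far as these compounds go, is whether pyridin-4-yl in the same place follows the larger or the smaller step.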